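A Methyl in Place of an Iodo

The source may hold more compounds than are shown below. What is called first, only, known or untested is meant among the compounds shown, and "the series" means these compounds.

In a functional assay on HeLa cells (Homo sapiens) for cytotoxicity, read by MTT assay, with a stated time of 48 h (a lower number here means a stronger inhibitor, a higher number a weaker inhibitor), compound 1 (`C=C1CCC[C@]2(C)CCC(C=O)=CC[C@@]12C`) gives 191000 nM and compound 2 (`CC1(C)CCCC2=CC=C(C=O)CC[C@]21C`) gives 163000 nM in the same test. Compound 3 (`C=C1CCC[C@]2(C)CCC(c3cn(-c4ccc(I)cc4)nn3)=CC[C@@]12C`) gives 144000 nM and stands within the usual scatter of both, so these numbers cannot separate the three compounds.

Compound 4 (`C=C1CCC[C@]2(C)CCC(c3cn(-c4ccc(C)cc4)nn3)=CC[C@@]12C`) has not been measured yet. It differs from compound 3 in one place: on an aromatic carbon of a six-membered aromatic ring of carbon only, para to a large group, methyl replaces iodo. This turns 4-iodophenyl into 4-methylphenyl (methyl in place of iodo on an aromatic carbon).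

Among the compounds with values here, no measured pair shows this exchange directly, so the guide is limited. Compound 3 at (144000 nM) lies within the scatter of compound 1 at (191000 nM) despite their different groups. A step beyond the scatter is therefore not expected in this assay, and the estimated change is small (a 1.0-fold higher number from compound 3 to compound 4 (0.02 log units; within the scatter)). Compound 4 is expected to give about (150000 nM), with an estimated range from 85000 nM to 260000 nM in this test.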

Compound 4, half-maximal inhibitory concentration: 69100 nM
Compound 4: middle estimate off by 2.2-fold (0.34 log units), on the high side, outside the stated range (below it).
By their numbers in this assay, from the lowest: compound 4; then compounds 3, 2 and 1 (each within the scatter of the next).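

In this assay, methyl in place of iodo gives a 2.1-fold lower number from compound 3 to compound 4 (0.32 log units; beyond the scatter), a modest step, but the only one here that lies beyond the usual scatter. It shows that the group on this aromatic carbon, para to a large group, can change the reading in this cell test, which the three earlier numbers could not show. Nothing available here explains why methyl reads lower than iodo.

With only these two groups seen at this place, a single pair cannot show whether the lower number belongs to methyl in particular or would also appear with a chloro or a methoxy group. On these data alone, it also remains open whether a longer chain, an amine or a carboxylic acid at the same place would lower the number further or raise it again.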